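Swapping Methyl for Chloro in a Potent Antiproliferative Compound

The source may hold more compounds than are shown below. What is called first, only, known or untested is meant among the compounds shown, and "the series" means these compounds.

Going by the values given here, in a functional assay on MDA-MB-435 cells (Homo sapiens) for antiproliferative activity, read by sulforhodamine B assay (a lower number here means a stronger inhibitor, a higher number a weaker inhibitor), compound 1 (`COc1cccc2cc(N(C)c3nc(C)nc4ccccc34)ccc12`) gives 2 nM and so stands lowest of the two numbers known. In this assay compound 2 (`COc1ccc(N(C)c2ncnc3ccccc23)cc1`) reads higher at 7.1 nM with a gap beyond the usual scatter. Compound 3 (`COc1cccc2cc(N(C)c3nc(Cl)nc4ccccc34)ccc12`) carries chloro in place of methyl on an aromatic carbon between two ring nitrogen atoms (chloro in place of methyl on an aromatic carbon). Among the compounds with values here, no measured pair isolates this change, so only a small rise in this assay is expected, within the scatter. The expected change is a 1.5-fold higher number from compound 1 to compound 3 (0.18 log units; within the scatter) on this estimate. For compound 3 the estimated value is 3 nM with an expected range of 1 nM to 10 nM in this measurement.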

Compound 3, half-maximal inhibitory concentration: 1.4 nM
Beside the measured number, compound 3's estimate is 2.1-fold (0.33 log units) above it, within the range that was stated.
By their numbers in this assay, from the lowest: compounds 3 and 1 (each within the scatter of the next); then compound 2.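

In this assay, putting chloro in place of methyl on the aromatic carbon between two ring nitrogen atoms gives a 1.4-fold lower number from compound 1 to compound 3 (0.15 log units; within the scatter), so the two compounds cannot be told apart. Going by these compounds alone, this is the first direct comparison at this position, and it shows that, on the core of compound 1, the carbon carries either of these two single-atom groups with no measurable difference. No measurement shown here explains this result. Still open, on these data alone, is how an amine or a carboxylic acid on this same carbon would read.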